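Series notes: fluoro for formyl at the aryl terminus

This account rests on a few compounds, and the source may have more. Where it says the series, first, only, none or still open, it means among the compounds named here.

Measured compounds:
compound 1, `Brc1cn2ccnc2c(-c2ccc3ncn(C4CCCCC4)c3c2)n1`, 16.2%
compound 2, `O=Cc1ccc(-c2cn3ccnc3c(-c3ccc4ncn(C5CCCCC5)c4c3)n2)cc1`, 25.3%

In a functional assay on NCI-H522 cells (Homo sapiens) for inhibition, read by sulforhodamine B assay, with a stated time of 48 h, tested at 10 uM (on this read-out lower numbers stand for less inhibition and higher numbers for more inhibition at the one concentration tested (going by the name of the read-out)), compound 2 gives 25.3%, and compound 1 gives 16.2%. Going by the values given here, the only measured step, a number 9.1 percentage points higher from compound 1 to compound 2 (within the scatter), lies within the scatter, so the two numbers cannot be told apart and neither compound can be said to give the higher inhibition in this assay.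

Compound 3, `Fc1ccc(-c2cn3ccnc3c(-c3ccc4ncn(C5CCCCC5)c4c3)n2)cc1`, is not yet measured. It differs from compound 2 by fluoro in place of formyl on an aromatic carbon. No measured step shows this kind of exchange; the one step shown concerns a different change at the same carbon and was itself within the scatter, so it gives no direction for the move from formyl to fluoro.

Compound 3 is therefore expected to stay close to compound 2, with a step of a number 3.3 percentage points lower from compound 2 to compound 3 (within the scatter) that is not expected to exceed the scatter. The estimate for compound 3 in this assay is 22%, ranging from 8% to 36%.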

Compound 3, a percentage reported as inhibition, at one concentration (the size of the read-out at that concentration, not a potency): 15.5%
For compound 3 the middle estimate is 6.5 percentage points above the measured one, and the stated range covers the measured number.
By their numbers in this assay, from the lowest: compounds 3, 1 and 2 (each within the scatter of the next).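

In this assay the change from 4-formylphenyl to 4-fluorophenyl reads as a number 9.8 percentage points lower from compound 2 to compound 3 (within the scatter) and so cannot be told apart from no change, which shows that the formyl group is not needed to reach the level of inhibition seen here. Fluoro in place of bromo is not the change at this carbon; the whole 4-fluorophenyl group in place of bromo reads as a number 0.7 percentage points lower from compound 1 to compound 3 (within the scatter) and, with the earlier 4-formylphenyl step, makes two aryl groups at this carbon that cannot be separated from bromo. No measurement at hand bears on why these numbers lie so close.

From the compounds shown here alone, whether an amine or a carboxylic acid in place of fluoro on this phenyl ring would give a step beyond the scatter remains open. Also open, going by these compounds, is whether the three compounds stay this close at any concentration other than the one tested.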